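Cyclopropyl replacing 3-fluorobenzyl on the exocyclic amine

The compounds below may be only part of what the source reports. "The series", "measured", "known", "first", "only" and "open" are said of these compounds alone.

Going by the values given here, compound 2 `CCCCC#Cc1nc(NCc2cccc(F)c2)c2ncn([C@H]3[C@H](O)[C@H](O)[C@@H]4C[C@@H]43)c2n1` gives 16 nM in an assay on CHO cells for displacement of a labelled ligand from adenosine receptor A3 (Homo sapiens), with a stated time of 60 min (on this read-out higher numbers stand for weaker inhibition and lower numbers for stronger inhibition), the higher of the two numbers so far; compound 1 `CCCCC#Cc1nc(NC)c2ncn([C@H]3[C@H](O)[C@H](O)[C@@H]4C[C@@H]43)c2n1` gives 4.9 nM. Among the compounds with values here, the only measured step, a 3.3-fold higher number from compound 1 to compound 2 (0.51 log units; beyond the scatter), bears directly on the present change, since it introduced the 3-fluorobenzyl that compound 3 now loses. Compound 3 `CCCCC#Cc1nc(NC2CC2)c2ncn([C@H]3[C@H](O)[C@H](O)[C@@H]4C[C@@H]43)c2n1` carries cyclopropyl in place of 3-fluorobenzyl on a nitrogen on an aromatic ring. Removing the whole 3-fluorobenzyl is expected to undo part of that step, though not necessarily all of it. For compound 3 a step of a 2.3-fold lower number from compound 2 to compound 3 (0.36 log units; beyond the scatter) in this assay is expected, giving an estimated 7 nM with a range of 2.5 nM to 20 nM.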

Compound 3, inhibition constant: 9.2 nM
Compound 3: the middle estimate sits 1.3-fold (0.12 log units) below what was measured; measured number inside the range.
By their numbers in this assay, from the lowest: compounds 1, 3 and 2 (each within the scatter of the next, the first and the last beyond it).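

Cyclopropylamino gives a 1.7-fold lower number from compound 2 to compound 3 (0.24 log units; within the scatter) and a 1.9-fold higher number from compound 1 to compound 3 (0.27 log units; within the scatter), so in this assay compound 3 cannot be told apart from either neighbour, although methyl and 3-fluorobenzyl on this nitrogen do differ beyond the scatter. A ring on the nitrogen is therefore compatible with numbers close to both, and the three compounds give no clear trend with group size. Nothing available explains these numbers.

Open, as far as these compounds go, is whether a cyclobutyl, an ethyl or an unfluorinated benzyl on this nitrogen would fall within the same narrow span. Also open, from the compounds shown here alone, is how an unsubstituted amine compares.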